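The compounds below may be only part of what the source reports. "The series", "measured", "known", "first", "only" and "open" are said of these compounds alone.

Of the compounds shown here, three built on a shared core have been tested in an assay on T47D cells for inhibition of Steryl-sulfatase (Homo sapiens), read by HPLC, with a stated time of 24 h; a higher number here means a weaker inhibitor, a lower number a stronger inhibitor. Compound 1 `Cc1cc(-c2ccc(C(=O)N(C)c3ccccc3C)o2)ccc1OS(N)(=O)=O` gives 570 nM. Compound 2 `Cc1ccccc1N(C)C(=O)c1ccc(-c2ccc(OS(N)(=O)=O)c(F)c2)o1` gives 17 nM. Compound 3 `Cc1ccc(F)cc1N(C)C(=O)c1ccc(-c2ccc(OS(N)(=O)=O)cc2)o1` gives 40 nM. Among the measured compounds shown here, the only measured change at a single point, a 34-fold lower number from compound 1 to compound 2 (1.53 log units; beyond the scatter), concerns a group on an aromatic carbon of the core and not the group on the amide-type nitrogen. Among the three numbers, compound 3 stands second highest: compound 2 sits lower, beyond the scatter, and compound 1 far higher.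

Compound 4 `Cc1cccnc1N(C)C(=O)c1ccc(-c2ccc(OS(N)(=O)=O)cc2)o1` differs from compound 3 by 3-methylpyridin-2-yl in place of 5-fluoro-2-methylphenyl on an amide-type nitrogen. For the measured compounds named here, no measured step touches this position, and compounds 2 and 3 differ at two places at once, so their values show only that a change at the amide-type nitrogen can coexist with a moderate gap. A step of modest size, in either direction, is therefore expected in this assay. Compound 4 is estimated at 60 nM, with a range from 15 nM to 250 nM. That estimate corresponds to an expected step of a 1.5-fold higher number from compound 3 to compound 4 (0.18 log units; within the scatter).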

Compound 4, half-maximal inhibitory concentration: 1100 nM
Estimate against measurement, compound 4: 18-fold (1.26 log units) below, and the stated range ends below it.
By their numbers in this assay, from the lowest: compound 2; then compound 3; then compounds 1 and 4 (each within the scatter of the next).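

The group on the amide-type nitrogen turns out to matter a great deal: 3-methylpyridin-2-yl in place of 5-fluoro-2-methylphenyl gives a 28-fold higher number from compound 3 to compound 4 (1.44 log units; beyond the scatter), so compound 4 is a much weaker inhibitor than compound 3. Among the compounds shown here, this is the first single change measured at this position, and it is large, as is the earlier change on an aromatic carbon of the core, a 34-fold lower number from compound 1 to compound 2 (1.53 log units; beyond the scatter). No measurement shown here explains why this swap weakens inhibition so strongly.

The swap removes the fluorine and also puts a nitrogen into the ring, and the compounds shown cannot say which of the two accounts for the step. From the compounds shown here alone, how this position would respond to quite different groups on the same nitrogen, such as a cyclohexyl group or a longer chain, also stays open.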